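Sulfonamide series: two limits and a 3,4-dichlorophenyl step

A few compounds are considered here, and "the series" means these few. Any claim that something is new, unique, unknown or untested is made for them only; others in the source may bear on it.

Measured so far:
compound 1 `O=S(=O)(Nc1ccc(-c2nc3ccccc3o2)cc1)c1ccccc1F`: > 63000 nM
compound 2 `O=S(=O)(Nc1ccc2oc(-c3ccccc3)nc2c1)c1cccc(Cl)c1`: > 63000 nM

Both values obtained in an assay on isolated protein for inhibition of malate dehydrogenase, mitochondrial (Sus scrofa), with stated times of 45 min and 30 min (on this read-out higher numbers stand for weaker inhibition and lower numbers for stronger inhibition), are limits of the measurement rather than numbers. Compound 1 gives only a limit, > 63000 nM. Compound 2 likewise gives only a limit, > 63000 nM. Compound 1 therefore stands at the limit of > 63000 nM in this assay, at which 2 of the 2 values shown sit, and no finite number exists anywhere in the series to rank it against.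

Compound 3 `O=S(=O)(Nc1ccc(-c2nc3ccccc3o2)cc1)c1ccc(Cl)c(Cl)c1` has not been measured. It differs from compound 1 by 3,4-dichlorophenyl in place of 2-fluorophenyl on a sulfonyl sulfur. No step between measured compounds is shown, so nothing measured indicates how that change acts in this assay. Given that every known value sits at the limit, compound 3 is expected to stay at or near it, a step that the limit leaves unreadable from compound 1 to compound 3, which is expected to mean no change beyond the scatter. Compound 3 is accordingly estimated at 70000 nM, within a range of 30000 nM to 200000 nM.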

Compound 3, half-maximal inhibitory concentration: > 63000 nM
Compound 3: a limit, no number; the forecaster's own chance of this, stated with the estimate: 85%; the middle value is on the limit's open side.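

In this assay compound 3 gives > 63000 nM, a limit and not a number. Compound 1 also gives only a limit, so no step between compound 1 and compound 3 can be read: the limit of > 63000 nM in this assay, at which 3 of the 3 values shown sit.

The compounds shown leave open whether any member of this sulfonamide series reaches a finite value in this assay.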